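The source may hold more compounds than are shown below. What is called first, only, known or untested is meant among the compounds shown, and "the series" means these compounds.

Working notes on the series. In a functional assay on HL60/MX2 cells (Homo sapiens) for antiproliferative activity, read by MTT assay, with a stated time of 48 h (a higher number here means a weaker inhibitor, a lower number a stronger inhibitor), compound 1 `N#Cc1nc2c(-c3nc4ccccc4o3)c(N)n(CCCN3CCCCC3)c2nc1C#N` gives 5450 nM, compound 2 `CN(C)CCCCn1c(N)c(-c2nc3ccccc3o2)c2nc(C#N)c(C#N)nc21` gives 960 nM and compound 3 `CCN(CC)CCCCn1c(N)c(-c2nc3ccccc3o2)c2nc(C#N)c(C#N)nc21` gives 1720 nM. Compound 2 sits at the low end of these numbers together with compound 3: a 1.8-fold higher number from compound 2 to compound 3 (0.25 log units; within the scatter), whereas a 5.7-fold lower number from compound 1 to compound 2 (0.75 log units; beyond the scatter) and a 3.2-fold lower number from compound 1 to compound 3 (0.50 log units; beyond the scatter).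

Next is compound 4 `CN(C)CCCCn1c(N)c(-c2nc3ccccc3s2)c2nc(C#N)c(C#N)nc21`, which keeps the 4-(dimethylamino)butyl group of compound 2 and carries 1,3-benzothiazol-2-yl in place of 1,3-benzoxazol-2-yl on an aromatic carbon.

None of the three measured steps touches this group. All of them change the chain, so they bear on the new step only as a guide to size, and the series holds no measurement of this exchange. The largest of them, a 5.7-fold lower number from compound 1 to compound 2 (0.75 log units; beyond the scatter), sets the width of the range. No step beyond the scatter is expected in this assay, in either direction.

The expected step is a 1.0-fold higher number from compound 2 to compound 4 (0.02 log units; within the scatter). For compound 4 the estimated value is 1000 nM, with an expected range from 330 nM to 3000 nM.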

Compound 4, half-maximal inhibitory concentration: 2140 nM
The estimate for compound 4 lay 2.1-fold (0.33 log units) below the measured number, and the stated range covers the measured number.
By their numbers in this assay, from the lowest: compounds 2, 3 and 4 (each within the scatter of the next, the first and the last beyond it); then compound 1.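

The aromatic carbon next to the ring atom that bears an amino group now has its first measured exchange: in this assay, with the 4-(dimethylamino)butyl group held fixed, 1,3-benzothiazol-2-yl in place of 1,3-benzoxazol-2-yl gives a 2.2-fold higher number from compound 2 to compound 4 (0.35 log units; beyond the scatter). The number at this position therefore responds to a change of one ring atom, oxygen to sulfur, although both groups have the same counts of heavy atoms, donors and acceptors; the step is modest. Nothing available explains this step.

From the compounds shown here alone, whether the exchange gives a step of similar size with the chains of compound 1 or compound 3 remains open. Also open, going by these compounds, is how this position responds to other groups, such as 1H-benzimidazol-2-yl or a plain phenyl ring.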